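A few compounds are considered here, and "the series" means these few. Any claim that something is new, unique, unknown or untested is made for them only; others in the source may bear on it.

Measured in a functional assay for inhibition, with Homo sapiens as the target; on this read-out higher numbers stand for weaker binding and lower numbers for tighter binding:
- compound 1 `N#Cc1ccc(C2OCC(C/C=C\CCC(=O)O)C(c3cccnc3)O2)cc1`: 1290 nM
- compound 2 `CC(C)(Oc1ccccc1)C1OCC(C/C=C\CCC(=O)O)C(c2cccnc2)O1`: 75.9 nM

Of these two compounds, compound 2 has the lower number, 75.9 nM, and so the tighter binding in this assay. Compound 3 `COc1ccc(OC(C)(C)C2OCC(C/C=C\CCC(=O)O)C(c3cccnc3)O2)cc1` differs from it in one place: methoxy in place of hydrogen on an aromatic carbon. This is methoxy in place of hydrogen on an aromatic carbon, para to a large group.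

Among the compounds with values here, only one measured step bears on this change: a 17-fold lower number from compound 1 to compound 2 (1.23 log units; beyond the scatter). That large step exchanged a whole group on a saturated ring carbon, so it shows that the group at that carbon can matter. It says little about one small addition to an aromatic ring. Within the data shown here, no measured compound carries a methoxy, so the data give no firm direction. The expected step is modest, and is estimated as a 1.2-fold lower number from compound 2 to compound 3 (0.07 log units; within the scatter). For compound 3 the estimated value is 65 nM, with an expected range from 22 nM to 200 nM.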

Compound 3, dissociation constant: 302 nM
Estimate against measurement, compound 3: 4.6-fold (0.67 log units) below, outside the stated range (above it).
By their numbers in this assay, from the lowest: compound 2; then compound 3; then compound 1.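

Going from phenoxy to 4-methoxyphenoxy gives a 4.0-fold higher number from compound 2 to compound 3 (0.60 log units; beyond the scatter) in this assay, so a single methoxy on this aromatic carbon, para to a large group, shifts the read-out towards weaker binding. Within the data shown here, the earlier comparison, a 17-fold lower number from compound 1 to compound 2 (1.23 log units; beyond the scatter), showed only that exchanging a whole group on the saturated ring carbon can matter; this step shows that even a small addition on the aromatic ring of that group can be felt, and that here it costs binding. Nothing available explains why the number rises with this change.

A single substituent cannot show whether this loss belongs to methoxy in particular or would follow any addition at this place. Fluorine, methyl or hydroxyl on the same aromatic carbon would help to separate those two readings.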